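Removing the Hydroxy Group from Compound 3

This account rests on a few compounds, and the source may have more. Where it says the series, first, only, none or still open, it means among the compounds named here.

Four compounds share one core. Compound 1 `Cc1cc(NC(=O)c2cc([N+](=O)[O-])ccc2Cl)cc(-c2nc3ccccc3s2)c1O` in an ADME assay for permeability, using PAMPA, at pH 7.4 (a lower number here means that the compound crosses the layer more slowly, a higher number that the compound crosses the layer faster), gives 48 10^-6 cm/s. Compound 2 `Cc1ccc(-c2nc3ccccc3s2)cc1NC(=O)c1cc([N+](=O)[O-])c(N2CCCCC2)cc1Cl` in this assay gives < 1 10^-6 cm/s, which is a limit of the assay and not a number. Compound 3 `O=C(Nc1ccc(O)c(-c2nc3ccccc3s2)c1)c1cc([N+](=O)[O-])ccc1Cl` in this assay gives "below limit of detection" (no number reported), so no single number is known for it. Going by the values given here, the only further guide to where compound 3 stands is the limit of < 1 10^-6 cm/s in this assay, at which 1 of the 3 values shown sits, at which one of the three values sits. The picture for compound 3 is therefore that it crosses the layer too slowly to be quantified, while compound 1 crosses readily.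

Compound 4 `O=C(Nc1cccc(-c2nc3ccccc3s2)c1)c1cc([N+](=O)[O-])ccc1Cl` is the one still to be measured. It differs from compound 3 in one place: hydrogen in place of hydroxy on an aromatic carbon. No measured pair differs in exactly this way, so the size of the step cannot be read from the numbers shown. Because compound 3 gives "below limit of detection" (no number reported), any measurable number for compound 4 in this assay would mark a step upward beyond the usual scatter. The estimate for compound 4 in this assay is 25 10^-6 cm/s, expected to fall between 3 10^-6 cm/s and 100 10^-6 cm/s, with a real chance that only a limit is again reported.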

Compound 4, apparent permeability in the ADME assay: 12 10^-6 cm/s
Compound 4: the middle estimate sits 2.1-fold (0.32 log units) above what was measured, within the range that was stated.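

Going by these compounds alone, compound 3 has no number in the ADME assay, and no step to compound 4 can be read there. In a physicochemical assay for solubility, read by spectrophotometry, in phosphate buffer, measured as kinetic solubility, with a stated time of 18 h, at pH 7.4 (a lower number here means a less soluble compound, a higher number a more soluble compound), compound 3 gives 23 nM and compound 4 gives 580 nM, which is a 25-fold higher number from compound 3 to compound 4 (1.40 log units; beyond the scatter). The compounds shown leave open how large the permeability step is when hydrogen takes the place of hydroxy on an aromatic carbon.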